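The source may hold more compounds than are shown below. What is called first, only, known or untested is meant among the compounds shown, and "the series" means these compounds.

Among the measured compounds shown here, in a functional assay on the whole organism (strain Sprague-Dawley) for inhibition, with Rattus norvegicus as the target, with a stated time of 10 min (on this read-out lower numbers stand for an effect already at smaller amounts and higher numbers for an effect only at larger amounts of compound), only two compounds have numbers so far. Compound 2 `CCOC(=O)c1cnc(-c2cc([N+](=O)[O-])ccc2OCC)[nH]c1=O` gives 5 mg/kg as the lower of the two, and compound 1 `CCOC(=O)C(=O)Nc1ccc(OCC)c(-c2ncc(C(=O)O)c(=O)[nH]2)c1` gives 25 mg/kg as the higher, a gap beyond the usual scatter. These two compounds differ in more than one place, so their gap cannot be tied to any single change.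

Compound 3 `CCOC(=O)C(=O)Nc1ccc(OCC)c(-c2ncc(C(=O)OCC)c(=O)[nH]2)c1` is the next to be measured. Its change from compound 2 is ((ethoxycarbonyl)carbonyl)amino in place of nitro on an aromatic carbon, meta to a large group and para to an ethoxy group (((ethoxycarbonyl)carbonyl)amino in place of nitro on an aromatic carbon). Compound 3 keeps the ethyl ester of compound 2, while compound 1 carries the same ((ethoxycarbonyl)carbonyl)amino group but has a carboxylic acid there instead. For the measured compounds named here, no measured pair shows this swap alone, so the expectation is loose. Going by the values given here, with compound 1 at 25 mg/kg as the only guide to the entering group, a move toward a higher number is expected, and the estimated size is a 2.0-fold higher number from compound 2 to compound 3 (0.30 log units; within the scatter) at about the edge of the scatter. For compound 3 the estimate is 10 mg/kg within an expected range of 3 mg/kg to 35 mg/kg in this assay.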

Compound 3, dose for 50% inhibition: 5 mg/kg
For compound 3 the middle estimate is 2.0-fold (0.30 log units) above the measured one, within the range that was stated.
By their numbers in this assay, from the lowest: compounds 2 and 3 (each within the scatter of the next); then compound 1.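

In this assay, putting ((ethoxycarbonyl)carbonyl)amino in place of nitro on the aromatic carbon para to an ethoxy group gives no change at the digits printed from compound 2 to compound 3 (within the scatter), so this position takes a larger group that also brings a hydrogen-bond donor, with no visible shift in the read-out. With that group held fixed, ethyl in place of hydrogen on an oxygen next to a carbonyl group gives a 5.0-fold lower number from compound 1 to compound 3 (0.70 log units; beyond the scatter), so the higher number of compound 1 goes with its carboxylic acid rather than with the group on the aromatic carbon. Nothing available here explains why either step comes out as it does.

The compounds shown leave open whether a plain amine or a shorter acetylamino group on this aromatic carbon would also keep the number where it stands. They also leave open whether a methyl ester or an amide could stand in for the ethyl ester, and whether the gain from the ester would be the same size with nitro on the aromatic carbon.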